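Adding a Chloro Group to a Purine Benzyl Chloride

A few compounds are considered here, and "the series" means these few. Any claim that something is new, unique, unknown or untested is made for them only; others in the source may bear on it.

Measured compounds:
Compound 1 `ClCc1ccccc1Cn1cnc2ncnc(Cl)c21` gives 4890 nM in a functional assay on OVCAR-4 cells (Homo sapiens) for cytotoxicity, read by sulforhodamine B assay, with a stated time of 48 h; on this read-out lower numbers stand for stronger inhibition of growth and higher numbers for weaker inhibition of growth.
Compound 2 `Nc1nc(Cl)c2ncn(Cc3cccc(CCl)c3)c2n1` gives 1950 nM in this assay.
Compound 3 `ClCc1ccc(Cn2cnc3ncnc(Cl)c32)cc1` gives "not determined" (no result reported) in this assay.

Compound 1 and compound 2 both sit in the micromolar region of this assay, and their two values show the range that this small set of benzyl chlorides covers. Among the measured compounds shown here, compound 3 stands apart: no number was obtained for it, so its place on this scale is unknown, and there is no measured pair here that differs in a single spot to set a reference step.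

Compound 4 `ClCc1ccc(Cn2cnc3nc(Cl)nc(Cl)c32)cc1` is compound 3 with one added atom: chloro in place of hydrogen on an aromatic carbon. With nothing measured for compound 3, the step from compound 3 to compound 4 in this assay is expected to be small, without a clear direction, and most likely within the usual scatter of the read-out. Taking the values of compound 1 and compound 2 as the only anchors, compound 4 is estimated to give about 3000 nM in this assay, with a plausible range from 1000 nM to 10000 nM.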

Compound 4, concentration for 50% growth inhibition: 2080 nM
Beside the measured number, compound 4's estimate is 1.4-fold (0.16 log units) above it; the measured number falls inside the stated range.
By their numbers in this assay, from the lowest: compounds 2 and 4 (each within the scatter of the next); then compound 1.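

No step can be read from compound 3 to compound 4: compound 3 has no number to set against the value of compound 4. The compounds shown leave open whether the added chloro changes growth inhibition at all. No further data bear on this result.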